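Acylguanidine series: chloro to ethyl next measurement

This account rests on a few compounds, and the source may have more. Where it says the series, first, only, none or still open, it means among the compounds named here.

Going by the values given here, compound 1 `Cc1cc(Cl)c(S(C)(=O)=O)cc1C(=O)N=C(N)N` is one of two compounds measured in a functional assay for inhibition of sodium/hydrogen exchanger (Oryctolagus cuniculus); on this read-out higher numbers stand for weaker inhibition and lower numbers for stronger inhibition; compound 1 gives 25 nM, the lowest of the two numbers. Among the compounds with values here, compound 2 `Cc1c(C(=O)N=C(N)N)cc(S(C)(=O)=O)c(Cl)c1C` gives 58 nM in this assay, and the step of a 2.3-fold higher number from compound 1 to compound 2 (0.37 log units; beyond the scatter) is the only measured step on record. Compound 3 `CCc1cc(C)c(C(=O)N=C(N)N)cc1S(C)(=O)=O` differs from compound 1 by ethyl in place of chloro on an aromatic carbon. Within the data shown here, no measured step touches this position or this exchange, so the only guide is the modest loss seen from compound 1 to compound 2 for an added carbon elsewhere. A small step toward a higher number, or none beyond the scatter, is expected, as a 1.8-fold higher number from compound 1 to compound 3 (0.26 log units; within the scatter). Compound 3 is estimated at 45 nM, within 15 nM to 140 nM.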

Compound 3, half-maximal inhibitory concentration: 4.8 nM
Estimate against measurement, compound 3: 9.4-fold (0.97 log units) above, outside the stated range (below it).
By their numbers in this assay, from the lowest: compound 3; then compound 1; then compound 2.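

On the aromatic carbon ortho to a methylsulfonyl group, chloro is not needed for inhibition: in this assay, ethyl in its place gives a 5.2-fold lower number from compound 1 to compound 3 (0.72 log units; beyond the scatter). Added carbon does not move the number one way across the series, as a 2.3-fold higher number from compound 1 to compound 2 (0.37 log units; beyond the scatter), at a different aromatic carbon, runs the other way. No supporting data explain the gain with ethyl. Open, from the compounds shown here alone, is how a propyl chain, a methyl group or an amine would read at this carbon. Also open, going by these compounds, is whether the lower number follows from gaining ethyl or from losing chloro.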